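A few compounds are considered here, and "the series" means these few. Any claim that something is new, unique, unknown or untested is made for them only; others in the source may bear on it.

Two measured members of this series frame the question. Compound 1 `COC1=C(CC(C)(C)CNC(=O)c2ccc3ccccc3c2OC)C(=O)c2ccccc2C1=O` gives 64100 nM in a functional assay on KB cells (Homo sapiens) for cytotoxicity, read by resazurin assay, with a stated time of 3 days; on this read-out higher numbers stand for weaker inhibition and lower numbers for stronger inhibition. Compound 2 `COc1cc(C(=O)NCC(C)(C)CC2=C(O)C(=O)c3ccccc3C2=O)c(OC)c2ccccc12` gives 47000 nM in this assay; the two values lie within the usual scatter of each other, so no ranking follows from them. Compound 3 `COC1=C(CC(C)(C)CNC(=O)c2cc(OC)c3ccccc3c2OC)C(=O)c2ccccc2C1=O` carries methyl in place of hydrogen on an oxygen on an unsaturated carbon relative to compound 2. Among the measured compounds shown here, no measured pair shows the effect of this change, so no step beyond the scatter is expected in either direction. For compound 3 the estimate is 50000 nM (range 20000 nM to 125000 nM), corresponding to an expected step of a 1.1-fold higher number from compound 2 to compound 3 (0.03 log units; within the scatter).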

Compound 3, half-maximal inhibitory concentration: 41200 nM
Estimate against measurement, compound 3: 1.2-fold (0.08 log units) above; low and high end bracket the measured number.
By their numbers in this assay, from the lowest: compounds 3, 2 and 1 (each within the scatter of the next).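

In this assay hydroxy to methoxy on an oxygen on an unsaturated carbon gives a 1.1-fold lower number from compound 2 to compound 3 (0.06 log units; within the scatter) for this position, so capping this oxygen with methyl leaves no readable difference. The methoxy in place of hydrogen on an aromatic carbon gives a 1.6-fold lower number from compound 1 to compound 3 (0.19 log units; within the scatter) and also stays inside the scatter. No supporting data bear on the reason for either result.

As far as these compounds go, whether a longer chain such as ethyl on this oxygen, or an amine in place of the methoxy, would step beyond the scatter remains open. The compounds shown also leave open which part of the structure, if any, moves this read-out.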